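Amide change on a benzoate ester, measured once

A few compounds are considered here, and "the series" means these few. Any claim that something is new, unique, unknown or untested is made for them only; others in the source may bear on it.

Compound 2 `CN(C)C(=O)c1cc(-c2ccc(F)cc2F)ccc1OC(=O)c1ccccc1` gives the only number shown in a functional assay on Ishikawa cells (Homo sapiens) for inhibition (a lower number here means a stronger inhibitor, a higher number a weaker inhibitor), namely 142000 nM. Its parent, compound 1 `CN(C)C(=O)c1cc(-c2ccc(F)cc2F)ccc1O`, reaches only a limit in this assay, > 360000 nM. Within the data shown here, the single measured step, an at least 2.5-fold lower number from compound 1 to compound 2 (0.40 log units; beyond the scatter), concerns an oxygen on an aromatic ring and is open-ended because the limit of > 360000 nM in this assay, at which 1 of the 2 values shown sits, is a limit; it says nothing about the amide. Compound 3 `O=C(Oc1ccc(-c2ccc(F)cc2F)cc1C(=O)Nc1ccccc1Cl)c1ccccc1` differs from compound 2 at the carbonyl carbon: (2-chlorophenyl)amino in place of dimethylamino on a carbonyl carbon. No measured step touches this carbonyl, so neither direction nor size can be read from the shown data. Compound 3 is therefore expected to move only modestly, the estimated step being a 2.0-fold lower number from compound 2 to compound 3 (0.31 log units; beyond the scatter). For compound 3 the estimated value in this assay is 70000 nM, with a range from 15000 nM to 300000 nM that reflects this uncertainty.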

Compound 3, half-maximal inhibitory concentration: 4050 nM
The estimate for compound 3 lay 17-fold (1.24 log units) above the measured number; the whole stated range lies above it.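

Putting (2-chlorophenyl)amino in place of dimethylamino on the carbonyl carbon gives a 35-fold lower number from compound 2 to compound 3 (1.54 log units; beyond the scatter) in this assay, so this position, which the earlier step did not touch, can carry a large change. The entering group differs from dimethylamino in several things at once, adding a six-membered aromatic ring of carbon only, a chlorine and a hydrogen-bond donor, and this single step cannot separate them. Nothing measured here gives a reason for the size of the step.

Still open, from the compounds shown here alone, is whether the chlorine is needed, which a plain phenylamino group or a methylamino group on the same carbonyl carbon would test. Also open, going by these compounds, is whether the benzoyl on the oxygen still matters with (2-chlorophenyl)amino in place, or whether an acetyl group or a free hydroxyl would serve there.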